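The source may hold more compounds than are shown below. What is called first, only, known or untested is meant among the compounds shown, and "the series" means these compounds.

Values in an ADME assay on Vero cells (Chlorocebus sabaeus) for cytotoxicity; on this read-out lower numbers stand for an effect already at smaller amounts and higher numbers for an effect only at larger amounts of compound:
- compound 1 `COc1ccc(Nc2ncnc3c(=N)n(NC(=O)c4ccncc4)cnc23)cc1`: 1.15 ug/mL
- compound 2 `N=c1c2ncnc(Nc3ccccc3)c2ncn1NC(=O)c1ccncc1`: 4.37 ug/mL
- compound 3 `CC(=O)Nn1cnc2c(Nc3ccccc3)ncnc2c1=N`: "not determined" (no result reported)

With 4.37 ug/mL, compound 2 has the higher of the two numbers available in this assay, and compound 3 offers no number to compare. The next compound to be tested, compound 4 `N=c1c2ncnc(Nc3ccc(F)cc3)c2ncn1NC(=O)c1ccncc1`, differs from compound 2 by fluoro in place of hydrogen on an aromatic carbon. In other words, phenyl becomes 4-fluorophenyl.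

Within the data shown here, only one measured step bears on this change: a 3.8-fold higher number from compound 1 to compound 2 (0.58 log units; beyond the scatter). That step is hydrogen in place of methoxy on an aromatic carbon, so the compound carrying the extra group, compound 1, has the lower number. Among the measured compounds shown here, a single step is thin evidence, and no measured compound yet carries fluoro. A small move towards a lower number is therefore expected, smaller than the step seen for compound 1 at 1.15 ug/mL. The estimated change is a 1.5-fold lower number from compound 2 to compound 4 (0.16 log units; within the scatter). Compound 4 is expected at about 3 ug/mL, with an estimated range from 1.2 ug/mL to 7.5 ug/mL.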

Compound 4, half-maximal effective concentration: 1.53 ug/mL
The estimate for compound 4 lay 2.0-fold (0.29 log units) above the measured number, within the range that was stated.
By their numbers in this assay, from the lowest: compounds 1 and 4 (each within the scatter of the next); then compound 2.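

In this assay, swapping hydrogen for fluoro, a change of one heavy atom on the aromatic carbon para to a large group, gives a 2.9-fold lower number from compound 2 to compound 4 (0.46 log units; beyond the scatter), so even this smallest of replacements moves the number at this position. Fluoro and methoxy cannot be told apart here, with a 1.3-fold higher number from compound 1 to compound 4 (0.12 log units; within the scatter), so two quite different groups both stand apart from the hydrogen of compound 2, and no compound with a number goes against this. Nothing available shows what lies behind this shift.

Still open, as far as these compounds go, is whether any group on this carbon would do the same: an amine or a carboxylic acid could fall with fluoro and methoxy or stay with hydrogen. From the compounds shown here alone, it is also open whether fluoro would give a similar step on another carbon of this ring.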